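This account rests on a few compounds, and the source may have more. Where it says the series, first, only, none or still open, it means among the compounds named here.

Working notes on the series.

The compounds share one core and differ only in the aryl group on the amine nitrogen. Compound 1 `Cc1ccc(S(=O)(=O)/N=C(/CCNC2=CC(=O)c3ccccc3C2=O)Nc2ccc(Cl)cc2)cc1` gives 13400 nM in a functional assay on HeLa cells (Homo sapiens) for cytotoxicity, read by MTT assay, with a stated time of 48 h; on this read-out lower numbers stand for stronger inhibition and higher numbers for weaker inhibition. Compound 2 `Cc1ccc(S(=O)(=O)/N=C(/CCNC2=CC(=O)c3ccccc3C2=O)Nc2ccc(F)cc2)cc1` gives 5890 nM in this assay, and compound 3 `COc1ccc(N/C(CCNC2=CC(=O)c3ccccc3C2=O)=N\S(=O)(=O)c2ccc(C)cc2)cc1OC` gives 14500 nM in this assay. Compound 2 has the lowest number of the three: the step of a 2.3-fold lower number from compound 1 to compound 2 (0.36 log units; beyond the scatter) and the step of a 2.5-fold higher number from compound 2 to compound 3 (0.39 log units; beyond the scatter) are both beyond the scatter, while compounds 1 and 3 sit within the scatter of each other, as a 1.1-fold higher number from compound 1 to compound 3 (0.03 log units; within the scatter) shows.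

Compound 4 `Cc1ccc(S(=O)(=O)/N=C(/CCNC2=CC(=O)c3ccccc3C2=O)Nc2ccc(F)c(F)c2)cc1` is not yet measured. Relative to compound 2 the change is fluoro in place of hydrogen on an aromatic carbon. Among the compounds with values here, the only measured step that touches this aryl group in a comparable way is the halogen swap from compound 1 to compound 2, which gave a 2.3-fold lower number from compound 1 to compound 2 (0.36 log units; beyond the scatter); no measured pair adds a second fluoro to an aryl group that already carries one. On that basis the expected step of a 1.2-fold lower number from compound 2 to compound 4 (0.07 log units; within the scatter) is small, with no confident direction, and compound 4 is estimated at 5000 nM in this assay, within a range of 2500 nM to 12000 nM.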

Compound 4, half-maximal inhibitory concentration: 8790 nM
For compound 4 the middle estimate is 1.8-fold (0.25 log units) below the measured one, within the range that was stated.
By their numbers in this assay, from the lowest: compounds 2, 4, 1 and 3 (each within the scatter of the next, the first and the last beyond it).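

In this assay, within the data shown here, the second fluoro, ortho to a fluoro group, adds no step that can be told from the scatter: a 1.5-fold higher number from compound 2 to compound 4 (0.17 log units; within the scatter). The 3,4-difluorophenyl group also does not separate from the other two aryl groups, with a 1.6-fold lower number from compound 3 to compound 4 (0.22 log units; within the scatter) and a 1.5-fold lower number from compound 1 to compound 4 (0.18 log units; within the scatter), so compound 4 overlaps all three earlier compounds, although compound 2 stands beyond the scatter of compound 1 and compound 3. No measurement shown accounts for this result.

Still open, going by these compounds, is whether a trifluoromethyl or a nitrile on this same aromatic carbon would give a step beyond the scatter from compound 2. The series also leaves open whether the 4-fluorophenyl group would keep its separation from the 4-chlorophenyl group if the tolyl sulfonyl part were replaced by a plain phenyl sulfonyl.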